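The source may hold more compounds than are shown below. What is called first, only, known or untested is meant among the compounds shown, and "the series" means these compounds.

In an ADME assay for pharmacokinetics, read by HPLC, in phosphate buffer, with a stated time of 72 h, at pH 7.4, tested at 250 uM (on this read-out higher numbers stand for a longer-lived compound and lower numbers for a shorter-lived compound), compound 1 `C=CC(=O)Oc1cc(C(F)(F)F)cc(C(F)(F)F)c1` gives a reading that is a limit of the assay, < 0.017 h. Compound 2 `Fc1cc(C(F)(F)F)cc(C(F)(F)F)c1` also gives only a limit, > 50 h. The step of an at least 2900-fold higher number from compound 1 to compound 2 (3.46 log units; beyond the scatter) is thus itself a lower bound, fixed by the limit in the limit of < 0.017 h in this assay, at which 1 of the 2 values shown sits, and the limit in the limit of > 50 h in this assay, at which 1 of the 2 values shown sits. Compound 3 `FC(F)(F)c1cc(S)cc(C(F)(F)F)c1` differs from compound 2 by sulfanyl in place of fluoro on an aromatic carbon. Among the compounds with values here, no measured step follows this particular change, and the single measured step concerns a different group, so it offers little guidance here. Compound 3 is expected to stay long-lived, with the step of an at least 1.6-fold lower number from compound 2 to compound 3 (0.22 log units; that floor lies within the scatter) estimated to be modest. The half-life of compound 3 is estimated at 30 h, between 5 h and 100 h.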

Compound 3, half-life: > 50 h
Compound 3 gave a limit, no number; the forecaster's own chance of this, stated with the estimate: 40%; middle value at least 1.6-fold (0.22 log units) away from the limit.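

In this assay compound 3 gives > 50 h, which is a limit of the assay. A second group, sulfanyl, therefore also sits at the long-lived end at this position, and sulfanyl in place of (vinylcarbonyl)oxy gives an at least 2900-fold higher number from compound 1 to compound 3 (3.46 log units; beyond the scatter). The step between fluoro and sulfanyl cannot be read because compound 2 and compound 3 stop at the same limit: the limit of > 50 h in this assay, at which 2 of the 3 values shown sit.

From the compounds shown here alone, how far past that limit either compound lasts stays open, so the two groups cannot be ranked. Also open, going by these compounds, is whether an amine or a carboxylic acid here would stay as long-lived or fall toward compound 1.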